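The source may report more compounds than this note shows. Statements on the series, on what has been measured and on what is new or still open speak of the compounds shown alone.

Measured compounds:
compound 1, `CC(C)n1ncnc1-c1ccccc1NCC1=NCCN1`, 0%
compound 2, `CCCCn1ncnc1-c1ccccc1NCC1=NCCN1`, 83%
compound 3, `Cn1ncnc1-c1ccccc1NCC1=NCCN1`, 93%

All three share one core and were read in a functional assay with Alpha-1B adrenergic receptor (Homo sapiens) as the target, read by calcium flux; a lower number here means a smaller maximal response, a higher number a larger maximal response. Compound 3 holds the highest of the three numbers, but its nearest neighbour, compound 2, lies within the scatter of it, so no order between these two can be read; compound 1 lies far below both. The unmeasured compound 4, `CCCn1ncnc1-c1ccccc1NCC1=NCCN1`, differs from compound 3 in one place: ethyl in place of hydrogen on a saturated chain carbon bound to an aromatic nitrogen. Two kinds of measured step bear on this change. The step of a number 10 percentage points higher from compound 2 to compound 3 (within the scatter) removes a propyl at the same place and moves the number only within the scatter. The steps of a number 83 percentage points higher from compound 1 to compound 2 (beyond the scatter) and a number 93 percentage points higher from compound 1 to compound 3 (beyond the scatter) are large, but both start from the isopropyl compound, and the two straight-chain compounds, compound 2 and compound 3, sit close together. Compound 4 carries a straight chain of length between those of compound 3 and compound 2, so no step beyond the scatter is expected in this assay. The step expected for compound 4 is a number 8 percentage points lower from compound 3 to compound 4 (within the scatter). Compound 4 is therefore estimated to give 85%, with a range from 62% to 100%.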

Compound 4, largest response reached (reported as maximal response), in percent of the reference or control that the assay uses: 74%
For compound 4 the middle estimate is 11 percentage points above the measured one, within the range that was stated.
By their numbers in this assay, from the lowest: compound 1; then compounds 4, 2 and 3 (each within the scatter of the next, the first and the last beyond it).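

In this assay, the earlier straight-chain pair, with methyl and butyl on the aromatic nitrogen, had shown no step beyond the scatter, yet the change from methyl to propyl gives a number 19 percentage points lower from compound 3 to compound 4 (beyond the scatter) as a modest step. The propyl and butyl chains cannot be separated, with a number 9 percentage points lower from compound 2 to compound 4 (within the scatter) in this assay, so the straight chains follow no clean order with length: the methyl and propyl compounds stand apart, while the butyl compound lies within the scatter of both. The propyl chain also stays far from the branched isopropyl, with a number 74 percentage points higher from compound 1 to compound 4 (beyond the scatter) as a large step, so a third straight chain keeps a large response and compound 1 remains the only one of the four far below the others.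

Nothing given here explains why these steps take the sizes they do. As far as these compounds go, it remains open whether other branched groups, such as tert-butyl or cyclopropyl, would read like isopropyl, and how a longer chain such as pentyl, or a chain ending in an amine, would read at this place.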